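A few compounds are considered here, and "the series" means these few. Any claim that something is new, unique, unknown or untested is made for them only; others in the source may bear on it.

Measured compounds:
compound 1, `Cc1c(OCCCCOc2ccc(C(=O)O)cc2F)ccc(C(=O)CC2CCCC2)c1O` — in an assay on HEK293 cells for positive allosteric modulation of metabotropic glutamate receptor 3 (Rattus norvegicus), read by thallium flux, with a stated time of 2.5 min (a lower number here means that less compound is needed, a higher number that more compound is needed for the effect), compound 1 gives > 10000 nM, which is a limit of this assay rather than a number.
compound 2, `Cc1c(OCCCCOc2ccccc2C(=O)O)ccc(C(=O)CC2CCCC2)c1O` — in this assay compound 2 gives "not determined" (no result reported).

Going by the values given here, compound 2 therefore has no single number to stand on; the one other value shown is a limit, as the limit of > 10000 nM in this assay, at which 1 of the 2 values shown sits, records. Compound 3, `Cc1c(OCCCCOc2cccc(C(=O)O)c2)ccc(C(=O)CC2CCCC2)c1O`, differs from compound 2 by 3-carboxyphenyl in place of 2-carboxyphenyl on an oxygen on a saturated carbon. Among the compounds with values here, with no measured step between these two carboxyphenyl arrangements, any expectation in this assay is loose, and the only reference point is the limit of compound 1, so no direction can be stated beyond the scatter. Compound 3 is estimated at 8000 nM, within a range of 1500 nM to 30000 nM.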

Compound 3, half-maximal effective concentration: 3400 nM
Compound 3: the middle estimate sits 2.4-fold (0.37 log units) above what was measured; measured number inside the range.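

Putting 3-carboxyphenyl in place of 4-carboxy-2-fluorophenyl on an oxygen on a saturated carbon gives an at least 2.9-fold lower number from compound 1 to compound 3 (0.46 log units; beyond the scatter) in this assay. Going by these compounds alone, this is the first number rather than a limit for this position, so the placement of the carboxyphenyl group does matter here. The true size of the step stays unknown, as compound 1 carries a limit: the limit of > 10000 nM in this assay, at which 1 of the 3 values shown sits.

The step moves the carboxylic acid and removes the fluorine together, and the two changes cannot be separated, while compound 2 gives no reading for 2-carboxyphenyl. On these data alone, whether a primary amide or a tetrazole in place of the carboxylic acid on the 3-carboxyphenyl ring would keep this activity also remains open.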